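The source may hold more compounds than are shown below. What is called first, only, known or untested is meant among the compounds shown, and "the series" means these compounds.

Measured so far in a functional assay on MDA-MB-231 cells (Homo sapiens) for cytotoxicity, read by MTT assay, with a stated time of 72 h; a lower number here means a stronger inhibitor, a higher number a weaker inhibitor:
- compound 1 `CN(C)CCNc1nc(-c2ccc(NC(=O)Nc3ccc(Cl)cc3)cc2)nc2c(Cl)c(Cl)sc12` gives 870 nM
- compound 2 `CN(C)CCNc1nc(-c2ccc(NC(=O)Nc3ccccc3Cl)cc2)nc2c(Cl)c(Cl)sc12` gives 1350 nM

Compound 2 carries the higher of the two numbers, but its nearest neighbour is compound 1 and the step of a 1.6-fold higher number from compound 1 to compound 2 (0.19 log units; within the scatter) lies within the scatter, so the two values cannot be ordered against each other.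

Compound 3 `CCN(CC)CCNc1nc(-c2ccc(NC(=O)Nc3ccccc3Cl)cc2)nc2c(Cl)c(Cl)sc12` differs from compound 2 in one place: diethylamino in place of dimethylamino on a saturated chain carbon, two bonds along the chain from a nitrogen on an aromatic ring. For the measured compounds named here, the only measured step, a 1.6-fold higher number from compound 1 to compound 2 (0.19 log units; within the scatter), varies the chlorophenyl end of the urea and leaves the chain amine untouched, so it does not bear on this change. Going by the values given here, no measured pair varies the amine at all; there is nothing in the data that would point to a shift in either direction. Under that, the expectation is no step beyond the scatter, carried forward from the value of compound 2 with a wide range to cover the absence of any guiding step. The step from compound 2 that this expectation means is no change at the digits printed from compound 2 to compound 3 (within the scatter). Compound 3 is therefore estimated at 1350 nM, with the range 550 nM to 3300 nM.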

Compound 3, half-maximal inhibitory concentration: 1410 nM
Estimate against measurement, compound 3: 1.0-fold (0.02 log units) below; the measured number falls inside the stated range.
By their numbers in this assay, from the lowest: compounds 1, 2 and 3 (each within the scatter of the next).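

In this assay, for the compounds shown here, the first measured change at the chain amine gives a 1.0-fold higher number from compound 2 to compound 3 (0.02 log units; within the scatter), so diethylamino in place of dimethylamino on a saturated chain carbon, two bonds along the chain from a nitrogen on an aromatic ring, leaves no readable difference with the 2-chlorophenyl urea in place. Going by these compounds alone, the earlier step concerned only the chlorophenyl end of the urea, so this is the first reading at the amine end of the series, and at this position either of the two amines gives values within the scatter of each other. Nothing available explains why the two amines read alike.

Whether the same holds with 4-chlorophenyl in place of 2-chlorophenyl stays open, as diethylamino is shown with only one urea end. Also open, on these data alone, is how a cyclic amine such as morpholine or piperidine, or a longer chain carrying the dimethylamino group, would read in this assay.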